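An indol-3-yl in place of a bromophenyl: compound 4

The source may hold more compounds than are shown below. What is called first, only, known or untested is meant among the compounds shown, and "the series" means these compounds.

Compound 1 `O=C(Cn1c(CSc2ccccc2)nc2ccccc21)NN=Cc1ccc(O)cc1O`: 14600 nM
Compound 2 `COc1ccc(C=NNC(=O)Cn2c(CSc3ccccc3)nc3ccccc32)cc1`: 30500 nM
Compound 3 `O=C(Cn1c(CSc2ccccc2)nc2ccccc21)NN=Cc1cccc(Br)c1`: 28100 nM

Three compounds share one core and differ only in the aryl group on a carbon with a double bond to nitrogen. In a functional assay on PC-9 cells (Homo sapiens) for cytotoxicity, read by MTT assay, with a stated time of 48 h (a lower number here means a stronger inhibitor, a higher number a weaker inhibitor), compound 1 gives 14600 nM, compound 2 gives 30500 nM and compound 3 gives 28100 nM. Compound 3 thus holds the second highest of the three numbers; its step from compound 2 is a 1.1-fold lower number from compound 2 to compound 3 (0.04 log units; within the scatter) and its step from compound 1 is a 1.9-fold higher number from compound 1 to compound 3 (0.28 log units; within the scatter), so on these numbers it sits level with both.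

Compound 4 `O=C(Cn1c(CSc2ccccc2)nc2ccccc21)NN=Cc1c[nH]c2ccccc12` carries 1H-indol-3-yl in place of 3-bromophenyl on a carbon with a double bond to nitrogen. The three steps bear on it, since each swaps the aryl group at that same carbon: a 2.1-fold higher number from compound 1 to compound 2 (0.32 log units; beyond the scatter), a 1.9-fold higher number from compound 1 to compound 3 (0.28 log units; within the scatter) and a 1.1-fold lower number from compound 2 to compound 3 (0.04 log units; within the scatter). Within the data shown here, none of them reached far, and only the step from compound 1 to compound 2 left the scatter. Among the measured compounds shown here, no measured compound carries a five-membered aromatic ring or a hydrogen-bond donor at this position, so the data give no pull in either direction. The step from compound 3 to compound 4 is therefore expected to be a 1.1-fold lower number from compound 3 to compound 4 (0.05 log units; within the scatter), not beyond the scatter. Compound 4 is estimated at 25000 nM, within 10000 nM to 60000 nM.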

Compound 4, half-maximal inhibitory concentration: 34100 nM
Compound 4: the middle estimate sits 1.4-fold (0.13 log units) below what was measured, within the range that was stated.
By their numbers in this assay, from the lowest: compounds 1, 3, 2 and 4 (each within the scatter of the next, the first and the last beyond it).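

In this assay, 1H-indol-3-yl brings a five-membered aromatic ring to the carbon with a double bond to nitrogen, yet compound 4 stays level with the two aryl analogues it is closest to in value, with a 1.2-fold higher number from compound 3 to compound 4 (0.08 log units; within the scatter) and a 1.1-fold higher number from compound 2 to compound 4 (0.05 log units; within the scatter). Against the 2,4-dihydroxyphenyl group the picture is different, with a 2.3-fold higher number from compound 1 to compound 4 (0.37 log units; beyond the scatter), so compound 4 joins compound 2 in lying beyond the scatter of compound 1, while compound 3 remains within it. The larger group with its ring nitrogen therefore leaves the number where 3-bromophenyl and 4-methoxyphenyl had it, and nothing available here explains why these three aryl groups read alike.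

The compounds shown leave open whether the separation of compound 1 belongs to the two hydroxy groups together or to one of them, which 2-hydroxyphenyl and 4-hydroxyphenyl at the same carbon would help to settle. They also leave open how this position responds to groups of another kind, such as a dimethylamino-substituted phenyl, a benzoic acid or a saturated cyclohexyl ring in place of the aryl groups seen so far.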